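A Second Chloro on the Core of Compound 2

The compounds below may be only part of what the source reports. "The series", "measured", "known", "first", "only" and "open" are said of these compounds alone.

Compound 1 `ClCc1ccccc1Cn1cnc2c(Cl)ncnc21`, compound 2 `ClCc1ccccc1Cn1cnc2ncnc(Cl)c21` and compound 3 `ClCc1ccc(Cn2cnc3c(Cl)nc(Cl)nc32)cc1` share a common core with a single aromatic arm. In a functional assay on SF-268 cells (Homo sapiens) for cytotoxicity, read by sulforhodamine B assay, with a stated time of 48 h (a higher number here means a weaker inhibitor of growth, a lower number a stronger inhibitor of growth), compound 1 gives 3230 nM, compound 2 gives 4780 nM and compound 3 gives 2510 nM. Compound 2 shows the highest number of the three, but its gaps to compound 1 and to compound 3 both lie within the scatter, so no ranking can be drawn. Compound 4 `ClCc1ccccc1Cn1cnc2nc(Cl)nc(Cl)c21` differs from compound 2 in one place: chloro in place of hydrogen on an aromatic carbon. For the measured compounds named here, no measured pair shows this change, so the data give no direct guide; only a small move, if any, toward a lower number is expected in this assay. Compound 4 is therefore estimated at 3000 nM, within a range from 1200 nM to 7500 nM. The expected step of a 1.6-fold lower number from compound 2 to compound 4 (0.20 log units; within the scatter) is modest.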

Compound 4, concentration for 50% growth inhibition: 3010 nM
Estimate against measurement, compound 4: 1.0-fold (0.00 log units) below, within the range that was stated.
By their numbers in this assay, from the lowest: compounds 3, 4, 1 and 2 (each within the scatter of the next).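

For the compounds shown here, this is the first comparison in the set that differs in only one place. With chloro in place of hydrogen on the aromatic carbon between two ring nitrogen atoms, this assay shows a 1.6-fold lower number from compound 2 to compound 4 (0.20 log units; within the scatter) and so stays within the scatter, which means that this change at this position has no readable effect on growth inhibition here. Nothing in the available data bears on why this is so. Going by these compounds, whether an amine or a methoxy group at the same place would behave like chloro remains open. So does whether the same change would give a similar result on another cell line.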